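A Benzyloxy Group Carried Over to a Second Core

The source may hold more compounds than are shown below. What is called first, only, known or untested is meant among the compounds shown, and "the series" means these compounds.

Compound 1, `CC/C(=C(/c1ccc(NC(=O)C(C)C)cc1)c1ccc(OC)cc1)c1ccccc1`, gives > 30000 nM in a functional assay on HeLa cells (Homo sapiens) for inhibition, read by trypan blue exclusion, with a stated time of 72 h; a higher number here means a weaker inhibitor of growth, a lower number a stronger inhibitor of growth; this value is a limit of the assay.
Compound 2, `CC/C(=C(/c1ccc(NC(=O)C(C)C)cc1)c1ccc(OC)cc1)c1ccc(OCc2ccccc2)cc1`, gives 4200 nM in this assay.
Compound 3, `CC/C(=C(/c1ccccc1)c1ccc(NC(=O)C(C)C)cc1)c1ccccc1`, gives 28100 nM in this assay.

Compound 1 and compound 2 share one core and differ in a single place: benzyloxy in place of hydrogen on an aromatic carbon. This change gave an at least 7.1-fold lower number from compound 1 to compound 2 (0.85 log units; beyond the scatter), a step whose true size is open at its upper end since compound 1 sits at the limit of > 30000 nM in this assay, at which 1 of the 3 values shown sits. Compound 3 has a different core; the difference between the two cores is not broken down here. Compound 4, `CC/C(=C(/c1ccccc1)c1ccc(NC(=O)C(C)C)cc1)c1ccc(OCc2ccccc2)cc1`, stands to compound 3 exactly as compound 2 stands to compound 1: benzyloxy in place of hydrogen on an aromatic carbon, the same change at the same place. The expectation for compound 4 rests on that earlier step, an at least 7.1-fold lower number from compound 1 to compound 2 (0.85 log units; beyond the scatter), transferred to the core of compound 3. Compound 4 is therefore expected to show a 6.2-fold lower number from compound 3 to compound 4 (0.80 log units; beyond the scatter). The estimated value of compound 4 in this assay is 4500 nM, expected to fall between 1500 nM and 14000 nM.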

Compound 4, concentration for 50% growth inhibition: > 30000 nM
Compound 4 ended at the assay's limit (the forecaster's own chance of this, stated with the estimate: 5%); middle value at least 6.6-fold (0.82 log units) away from the limit.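

Compound 4 gives > 30000 nM in this assay, and this value is a limit of the assay. On the core of compound 3, benzyloxy in place of hydrogen gave an at least 1.0-fold higher number from compound 3 to compound 4 (0.02 log units; that floor lies within the scatter), so the lower number seen on the core of compound 1 did not carry over, and the two steps differ: the same change on two cores in this assay, an at least 7.1-fold lower number (0.85 log units; beyond the scatter) from compound 1 to compound 2 and an at least 1.0-fold higher number (0.02 log units; that floor lies within the scatter) from compound 3 to compound 4, at least 7.6-fold (0.88 log units) apart, beyond the scatter of two such steps. On these data alone, the result does not fix the true size of the new step, which stays open at its upper end, and it does not show what sets the two cores apart: the limit of > 30000 nM in this assay, at which 2 of the 4 values shown sit.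

As far as these compounds go, whether an amine or a carboxylic acid in place of benzyloxy would give a lower number on the core of compound 3 stays open. From the compounds shown here alone, it also stays open whether any such change would act alike on both cores.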